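This account rests on a few compounds, and the source may have more. Where it says the series, first, only, none or still open, it means among the compounds named here.

Measured compounds:
Compound 1 `CCCCC#Cc1cn([C@@H]2O[C@H](CO)[C@@H](O)[C@H]2O)c(=O)[nH]c1=O` gives 83200 nM in an ADME assay on A549 cells (Homo sapiens) for cytotoxicity, read by MTT assay; on this read-out lower numbers stand for higher toxicity in this test and higher numbers for lower toxicity in this test.
Compound 2 `O=c1[nH]cc(C#CC2CC2)c(=O)[nH]1` gives 251000 nM in this assay.
Compound 3 `O=c1[nH]c(=O)n([C@@H]2O[C@H](CO)[C@@H](O)[C@H]2O)cc1C#CC1CC1` gives 115000 nM in this assay.

Compound 2 stands at the highest number of the three in this assay; its gap to compound 3 and its gap to compound 1 both lie beyond the scatter. Compound 1 and compound 3 share a core and differ in one place: butyl in place of cyclopropyl on a triple-bonded carbon. That change gave a 1.4-fold lower number from compound 3 to compound 1 (0.14 log units; within the scatter), a step that falls within the scatter, so the two values show no real movement.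

Compound 2 and compound 3 carry different cores; the difference between the two cores is not broken down here.

The unmeasured compound 4 `CCCCC#Cc1c[nH]c(=O)[nH]c1=O` is related to compound 2 by the same change, in the same place: butyl in place of cyclopropyl on a triple-bonded carbon. Among the compounds shown, this change occurs twice, once measured and once still open. Because the measured instance gave a 1.4-fold lower number from compound 3 to compound 1 (0.14 log units; within the scatter), the expected step from compound 2 to compound 4 in this assay is a 1.4-fold lower number from compound 2 to compound 4 (0.14 log units; within the scatter), of about the same modest size, and it rests on that single pair alone; whether the change behaves alike on the core of compound 2 is not shown by any measured pair.

Compound 4 is therefore expected to give 180000 nM in this assay, with a plausible range from 90000 nM to 360000 nM.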

Compound 4, half-maximal cytotoxic concentration: 250000 nM
The estimate for compound 4 lay 1.4-fold (0.14 log units) below the measured number; low and high end bracket the measured number.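

In this assay, butyl in place of cyclopropyl on a triple-bonded carbon gave a 1.0-fold lower number from compound 2 to compound 4 (0.00 log units; within the scatter), so on the core of compound 2, as on the core of compound 1, the two values of the pair stand within the scatter of each other. Set side by side, the two steps do not differ, and the change carried from one core to the other without a measurable difference: the same change on two cores in this assay, a 1.4-fold lower number (0.14 log units; within the scatter) from compound 3 to compound 1 and a 1.0-fold lower number (0.00 log units; within the scatter) from compound 2 to compound 4, 1.4-fold (0.14 log units) apart, within the scatter of two such steps

Among the compounds shown here, this shows that, for these two cores and this one pair of groups, the step on one core was a fair guide to the step on the other, but since neither step lies beyond the scatter, it shows only that the change was without a readable effect on both cores, not that a larger effect would carry over in the same way.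

The compounds shown leave open whether a longer chain, an amine or a carboxylic acid in place of butyl on a triple-bonded carbon would give a step beyond the scatter in this assay. They also leave open whether the agreement between the two steps would hold on any third core, or in a cytotoxicity test on other cells.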